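This account rests on a few compounds, and the source may have more. Where it says the series, first, only, none or still open, it means among the compounds named here.

Measured in a physicochemical assay for solubility, read by nephelometry, measured as kinetic solubility, at pH 2.0; a higher number here means a more soluble compound, a lower number a less soluble compound:
- Compound 1 `CC(C)(C)c1cc(C(=O)Nc2cccc(CN)c2)n(Cc2ccccc2)n1`: > 100 ug/mL (a limit)
- Compound 2 `CC(=O)NCc1csc(NC(=O)c2cc(C(C)(C)C)nn2Cc2ccccc2)n1`: 12.5 ug/mL
- Compound 3 `CN(C)Cc1csc(NC(=O)c2cc(C(C)(C)C)nn2Cc2ccccc2)n1`: > 100 ug/mL (a limit)

Compound 3 has no exact number and stands at the limit of > 100 ug/mL in this assay, at which 2 of the 3 values shown sit. Compound 4 `CC(C)(C)c1cc(C(=O)Nc2nc(CNS(C)(=O)=O)cs2)n(Cc2ccccc2)n1` carries methanesulfonamido in place of dimethylamino on a saturated chain carbon bound to an aromatic carbon. The closest measured change sits on that same carbon: an at least 8.0-fold higher number from compound 2 to compound 3 (0.90 log units; beyond the scatter), with dimethylamino in place of acetamido. The other step, a step that the two limits leave unreadable from compound 1 to compound 3, gives no size. Compound 4 also loses dimethylamino, so that step is expected to run roughly in reverse, with compound 2 at 12.5 ug/mL as the guide. The step expected in this assay is an at least 6.6-fold lower number from compound 3 to compound 4 (0.82 log units; beyond the scatter), downward and beyond the scatter. For compound 4 the estimated value is 15 ug/mL, with an expected range of 5 ug/mL to 50 ug/mL.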

Compound 4, solubility: 3.1 ug/mL
Compound 4: the middle estimate sits 4.8-fold (0.68 log units) above what was measured; measured number below the stated range.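

In this assay, the change to methanesulfonamido on this saturated chain carbon gives an at least 32-fold lower number from compound 3 to compound 4 (1.50 log units; beyond the scatter). The value of compound 3 in that step is a limit, so the true size of the step stays unread. Among the compounds shown here, the amine nitrogen also proves sensitive to which group it carries, which the earlier compounds did not show, with methylsulfonyl in place of acetyl giving a 4.0-fold lower number from compound 2 to compound 4 (0.61 log units; beyond the scatter).

The compounds shown leave open how a primary amine or a carboxylic acid on this carbon would read. They also leave open whether a longer chain before the methanesulfonamido group would change the number.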